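The source may hold more compounds than are shown below. What is called first, only, known or untested is meant among the compounds shown, and "the series" means these compounds.

Measured in a functional assay on HT-29 cells (Homo sapiens) for cytotoxicity, read by MTT assay, with a stated time of 72 h; on this read-out lower numbers stand for stronger inhibition and higher numbers for weaker inhibition:
- compound 1 `NCCCNc1c(C(=O)NCc2ccc(F)cc2)nc(Br)c2cccnc12`: "not determined" (no result reported)
- compound 2 `CN(C)CCCNc1c(C(=O)NCc2ccc(F)cc2)nc(Br)c2cccnc12`: 6000 nM
- compound 3 `CNCCCNc1c(C(=O)NCc2ccc(F)cc2)nc(Br)c2cccnc12`: > 10000 nM

Compound 1 has no number of its own in this assay, so the step under consideration has no measured starting point. Compound 3 sits at a limit of the assay, and it accounts for (the limit of > 10000 nM in this assay, at which 1 of the 3 values shown sits).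

The next compound is compound 4 `NCCCNc1c(C(=O)NCc2ccc(F)cc2)ncc2cccnc12`, which differs from compound 1 as follows: hydrogen in place of bromo on an aromatic carbon. Hydrogen stands in place of bromo on an aromatic carbon, para to the (3-aminopropyl)amino group.

Among the compounds with values here, the only measured step is an at least 1.6-fold higher number from compound 2 to compound 3 (0.22 log units; that floor lies within the scatter). It concerns an amine nitrogen, not the bromo position, so it gives neither a size nor a direction for this change. No step beyond the scatter can therefore be predicted in this assay, and compound 4 is simply expected to fall in the same weak region as its relatives, with a limit result quite possible. The estimated value for compound 4 is 10000 nM, with an expected range of 3000 nM to 30000 nM.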

Compound 4, half-maximal inhibitory concentration: > 10000 nM
Compound 4: no number, only a limit; the forecaster's own chance of this, stated with the estimate: 50%; the middle value lies on the limit itself.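

In this assay compound 4 gives > 10000 nM, which is a limit and not a number. Within the data shown here, compound 1 has no number of its own, so no step between compound 1 and compound 4 can be read. The compounds shown leave open whether hydrogen in place of bromo changes cytotoxicity, and in which direction.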